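The compounds below may be only part of what the source reports. "The series", "measured", "known", "first", "only" and "open" are said of these compounds alone.

Measured in a functional assay on HeLa cells (Homo sapiens) for inhibition, read by MTT assay, with a stated time of 72 h; on this read-out higher numbers stand for weaker inhibition and lower numbers for stronger inhibition:
- compound 1 `CNC(=O)CCCCCCCn1nc(-c2cnc3[nH]ccc3c2)c2c(N)ncnc21`: 29100 nM
- compound 2 `Nc1nc2cc(-c3nn(CCCC(=O)NO)c4ncnc(N)c34)ccc2o1`: > 150000 nM

The entry for compound 2 is a limit and not a number, (the limit of > 150000 nM in this assay, at which 1 of the 2 values shown sits). Compound 3 `Nc1nc2cc(-c3nn(CCCCCC(=O)NO)c4ncnc(N)c34)ccc2o1` carries 2-(hydroxycarbamoyl)ethyl in place of hydroxycarbamoyl on a saturated chain carbon, three bonds along the chain from an aromatic nitrogen. Going by the values given here, no measured step covers this change. Stronger inhibition in this assay is expected, of uncertain size, with compound 1 at 29100 nM as the only numerical anchor. The expected step is an at least 5.0-fold lower number from compound 2 to compound 3 (0.69 log units; beyond the scatter). For compound 3 the estimated value is 30000 nM, with an expected range of 5000 nM to 150000 nM.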

Compound 3, half-maximal inhibitory concentration: 15400 nM
Compound 3: middle estimate off by 1.9-fold (0.29 log units), on the high side; the measured number falls inside the stated range.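

On the shared core, 2-(hydroxycarbamoyl)ethyl in place of hydroxycarbamoyl on a saturated chain carbon, three bonds along the chain from an aromatic nitrogen, gives an at least 9.7-fold lower number from compound 2 to compound 3 (0.98 log units; beyond the scatter) in this assay. Going by these compounds alone, this is the first measured step at this position, and it shows that a change in chain length alone moves the read-out beyond the scatter. The entry for compound 2 is a limit and not a number, so the full size of the step stays unknown: the limit of > 150000 nM in this assay, at which 1 of the 3 values shown sits.

Two compounds fix no trend with chain length. From the compounds shown here alone, whether a longer chain gives a still lower number, and whether a carboxylic acid can stand in place of the hydroxycarbamoyl end, remains open.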